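A few compounds are considered here, and "the series" means these few. Any claim that something is new, unique, unknown or untested is made for them only; others in the source may bear on it.

Compound 1 `CCc1cnc2c(C#N)c(N3CCC(c4ccccc4)CC3)ccn12` and compound 2 `CCCc1cnc2c(C#N)c(N3CCC(c4ccccc4)CC3)ccn12` share a core and differ at one saturated chain carbon two bonds along the chain from an aromatic carbon. In a functional assay on CHO cells for positive allosteric modulation of metabotropic glutamate receptor 2 (Homo sapiens), read by GTPgammaS binding, with a stated time of 30 min (a lower number here means a smaller maximal response, a higher number a larger maximal response), compound 1 gives 225%, while compound 2 gives 254%, the higher of the two numbers, and the step of a number 29 percentage points higher from compound 1 to compound 2 (beyond the scatter) lies beyond the scatter. Compound 3 `N#Cc1c(N2CCC(c3ccccc3)CC2)ccn2c(CC(F)(F)F)cnc12` carries the change (trifluoromethyl in place of ethyl on a saturated chain carbon bound to an aromatic carbon). Going by the values given here, no measured step tests this kind of change; the only step known, methyl in place of hydrogen, sits further out on the chain and was modest. The step is therefore expected to fall roughly as a number 14 percentage points lower from compound 2 to compound 3 (beyond the scatter), within or near the scatter. Compound 3 is estimated at 240%, with a range from 190% to 290%.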

Compound 3, largest response reached (Emax), in percent of the reference or control that the assay uses: 259%
Estimate against measurement, compound 3: 19 percentage points below, and the stated range covers the measured number.
By their numbers in this assay, from the lowest: compound 1; then compounds 2 and 3 (each within the scatter of the next).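

In this assay, the step with trifluoromethyl in place of ethyl on this chain reads a number 5 percentage points higher from compound 2 to compound 3 (within the scatter) and so shows no change in maximal response, which means this saturated chain carbon accepts the heavier fluorinated end group. Measured against the shorter chain of compound 1, the same group gives a number 34 percentage points higher from compound 1 to compound 3 (beyond the scatter) and keeps the gain that compound 2 had shown. Nothing shown accounts for this result. Going by these compounds, whether a hydroxyl group, an amine or a longer fluorinated chain would hold the response at this place remains open.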